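Swapping a branched chain tip for a straight one

The source may hold more compounds than are shown below. What is called first, only, known or untested is meant among the compounds shown, and "the series" means these compounds.

Compound 1, `CC(C)/C=C/C(=O)Nc1cc2c(N3CCc4ccccc43)ncnc2cc1O[C@@H]1CCOC1`, gives 8520 nM in a functional assay on A549 cells (Homo sapiens) for antiproliferative activity, read by MTT assay, with a stated time of 72 h; a higher number here means a weaker inhibitor, a lower number a stronger inhibitor.
Compound 2, `CCC/C=C/C(=O)Nc1cc2c(N3CCc4ccccc43)ncnc2cc1O[C@@H]1CCOC1`, gives 9110 nM in this assay.
Compound 3, `CC(C)/C=C/C(=O)Nc1cc2c(N3CCCc4ccccc43)ncnc2cc1O[C@@H]1CCOC1`, gives 6820 nM in this assay.

Compound 4, `CCC/C=C/C(=O)Nc1cc2c(N3CCCc4ccccc43)ncnc2cc1O[C@@H]1CCOC1`, has not yet been measured. It differs from compound 3 by propyl in place of isopropyl on a double-bonded chain carbon bound to a double-bonded chain carbon. The same change has already been made once among the measured compounds, from compound 1 to compound 2, where it gave a 1.1-fold higher number from compound 1 to compound 2 (0.03 log units; within the scatter). The cores of those two pairs differ by 1,2,3,4-tetrahydroquinolin-1-yl in place of 2,3-dihydro-1H-indol-1-yl on an aromatic carbon; the place of the change is described in the same words in both pairs, so it is the same change. Within the measured set, a 1.2-fold lower number from compound 1 to compound 3 (0.10 log units; within the scatter) shows that the core swap itself moved little. From compound 3 to compound 4 the step is expected to be a 1.1-fold higher number from compound 3 to compound 4 (0.03 log units; within the scatter), resting on the step of a 1.1-fold higher number from compound 1 to compound 2 (0.03 log units; within the scatter). Compound 4 is therefore expected to give about 7300 nM in this assay, likely between 3600 nM and 15000 nM.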

Compound 4, half-maximal inhibitory concentration: 7320 nM
For compound 4 the middle estimate is 1.0-fold (0.00 log units) below the measured one, and the stated range covers the measured number.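

In this assay, propyl in place of isopropyl gives a 1.1-fold higher number from compound 3 to compound 4 (0.03 log units; within the scatter), which agrees with the same change on the other core: the same change on two cores in this assay, a 1.1-fold higher number (0.03 log units; within the scatter) from compound 1 to compound 2 and a 1.1-fold higher number (0.03 log units; within the scatter) from compound 3 to compound 4, 1.0-fold (0.00 log units) apart, within the scatter of two such steps
With the propyl chain in place, 1,2,3,4-tetrahydroquinolin-1-yl in place of 2,3-dihydro-1H-indol-1-yl gives a 1.2-fold lower number from compound 2 to compound 4 (0.10 log units; within the scatter), which agrees with the earlier swap: the same change on two cores in this assay, a 1.2-fold lower number (0.10 log units; within the scatter) from compound 1 to compound 3 and a 1.2-fold lower number (0.10 log units; within the scatter) from compound 2 to compound 4, 1.0-fold (0.00 log units) apart, within the scatter of two such steps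
Both changes therefore carry over between these two cores, but every step lies within the scatter, so this does not show that a change with a large effect would carry over equally well, and two cores cannot speak for the whole series.

The compounds shown leave open whether an amine at the chain tip, or a longer chain, would move the number in this assay. They also leave open whether such a step would be the same on both cores.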